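A few compounds are considered here, and "the series" means these few. Any claim that something is new, unique, unknown or untested is made for them only; others in the source may bear on it.

Measured so far, in a functional assay on A549 cells (Homo sapiens) for antiproliferative activity, read by MTT assay, with a stated time of 24 h; a lower number here means a stronger inhibitor, a higher number a weaker inhibitor:
compound 1, `COc1ccc(-c2cc(/C=C/C(=O)c3cc(OC)c(OC)c(OC)c3)nc3cc(-c4ccccc4)nn23)cc1OC`, gives 7200 nM
compound 2, `COc1ccc(-c2cc(/C=C/C(=O)c3ccc(OC)c(OC)c3)nc3cc(-c4ccccc4)nn23)cc1`, gives 7400 nM
compound 3, `COc1cc(-c2cc(/C=C/C(=O)c3ccc(C)c(C)c3)nc3cc(-c4ccccc4)nn23)cc(OC)c1OC`, gives 10600 nM

Compound 1 has the lowest of the three numbers, but its distance to compound 2 and to compound 3 lies within the usual scatter of this kind of measurement, so the three compounds cannot be told apart on these values; none of them can be called the strongest or the weakest. All three share the same core, and they differ only in the aromatic groups attached at either end of it.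

Compound 4, `COc1ccc(C(=O)/C=C/c2cc(-c3ccc(OC)c(OC)c3)n3nc(-c4ccccc4)cc3n2)cc1`, has not yet been tested. Compared with compound 1, it differs in a single place:

4-methoxyphenyl in place of 3,4,5-trimethoxyphenyl on a carbonyl carbon

Within the data shown here, no pair of measured compounds differs in exactly one place, so there is no directly comparable step to lean on. What the three values do show is that swapping methoxy-bearing or methyl-bearing aromatic groups at either end of the core left all numbers close together. On that basis the step from compound 1 to compound 4 is expected to be small, with a slight lean toward a higher number, and quite possibly no change beyond the scatter; the expected step is a 1.3-fold higher number from compound 1 to compound 4 (0.10 log units; within the scatter). Compound 4 is therefore estimated at 9000 nM, with a likely range from 4000 nM to 22000 nM in this assay.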

Compound 4, half-maximal inhibitory concentration: 11900 nM
For compound 4 the middle estimate is 1.3-fold (0.12 log units) below the measured one; the range from low to high includes it.
By their numbers in this assay, from the lowest: compounds 1, 2, 3 and 4 (each within the scatter of the next).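

Among these compounds, compound 4 gives the first comparison in this set in which only one place changes: in this assay, putting 4-methoxyphenyl in place of 3,4,5-trimethoxyphenyl on a carbonyl carbon gives a 1.7-fold higher number from compound 1 to compound 4 (0.22 log units; within the scatter) and so leaves the two compounds indistinguishable. The group that enters has fewer heavy atoms and fewer hydrogen-bond acceptors than the group that leaves, so in this one pair, a smaller group with fewer methoxy groups on the carbonyl carbon produces no difference that can be separated from ordinary assay variation. No measurement shown here offers an explanation for this result.

On these data alone, all four compounds carry a phenyl ring with methoxy or methyl groups on this carbonyl carbon, so it remains open whether a ring bearing an amine or a carboxylic acid, or a longer chain in place of the ring, would shift the number beyond the scatter. As far as these compounds go, it is also open whether the same exchange would give a similar step with different aromatic groups elsewhere on the shared core.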